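Carbamate chain shortened on a selenocyanate aryl carbamate

A few compounds are considered here, and "the series" means these few. Any claim that something is new, unique, unknown or untested is made for them only; others in the source may bear on it.

Of the compounds shown here, three have been measured in a physicochemical assay, with a stated time of 180 min, tested at 0.5 mg/mL; on this read-out lower numbers stand for less inhibition and higher numbers for more inhibition at the one concentration tested (going by the name of the read-out). Compound 1 `O=C(Nc1ccc([Se][Se]c2ccc(NC(=O)OCc3ccccc3)cc2)cc1)OCc1ccccc1` gives 7.4%, compound 2 `CCCCOC(=O)Nc1ccc([Se]C#N)cc1` gives 6.6%, and compound 3 `CCCCOC(=O)Nc1ccc([Se][Se]c2ccc(NC(=O)OCCCC)cc2)cc1` gives 36.1%. Compound 2 and compound 1 give numbers within the scatter of each other, while compound 3 gives a number that is higher than compound 2 by more than the scatter. Compound 4 `CCOC(=O)Nc1ccc([Se]C#N)cc1` has not yet been measured; it differs from compound 2 by hydrogen in place of ethyl on a saturated chain carbon, two bonds along the chain from an oxygen next to a carbonyl group. Among the measured compounds shown here, no step between measured compounds isolates this change, and the two compounds that differ only in the carbamate chain are not available for comparison here. The change is expected to move this assay by little, a number 1.4 percentage points higher from compound 2 to compound 4 (within the scatter), not beyond the scatter. Compound 4 is therefore estimated to give 8%, between 0% and 20%.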

Compound 4, a percentage reported as inhibition, at one concentration (the size of the read-out at that concentration, not a potency): 37%
For compound 4 the middle estimate is 29 percentage points below the measured one; the whole stated range lies below it.
By their numbers in this assay, from the lowest: compounds 2 and 1 (each within the scatter of the next); then compounds 3 and 4 (each within the scatter of the next).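

Shortening the carbamate chain from butyl to ethyl gives a number 30.4 percentage points higher from compound 2 to compound 4 (beyond the scatter) in this assay. The earlier compounds shown here offered no pair that could test this position, and it now proves sensitive to a change involving only a saturated chain. Nothing available accounts for the size of this step.

A single step cannot show whether the number follows chain length, so a methyl, propyl or hexyl chain on the core of compound 2 remains an open comparison. Going by these compounds, whether an ethyl chain would act similarly on the core of compound 3 also remains open.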